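Adding ethoxy to the acetamide of compound 2

This account rests on a few compounds, and the source may have more. Where it says the series, first, only, none or still open, it means among the compounds named here.

Measured so far in a functional assay on A2780 cells (Homo sapiens) for antiproliferative activity, read by MTT assay, with a stated time of 48 h; a lower number here means a stronger inhibitor, a higher number a weaker inhibitor
compound 1 `C=C(c1ccc2c(c1)C=CC(C)(C)O2)c1ccc(OC)cc1NC(=O)CN(C)C` gives 510 nM
compound 2 `C=C(c1cc(OC)c(OC)c(OC)c1)c1ccc(OC)c(O)c1NC(C)=O` gives 170 nM

Of these two numbers, compound 2 holds the lower one (170 nM). Its gap to compound 1 lies beyond the usual scatter of repeated measurements, so compound 2 is the stronger inhibitor of the pair. The two compounds differ in more than one place, however, so the gap cannot be tied to any single group.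

Compound 3 `C=C(c1cc(OC)c(OC)c(OC)c1)c1ccc(OC)c(O)c1NC(=O)COCC` is compound 2 with one change (ethoxy in place of hydrogen on a saturated chain carbon bound to a carbonyl carbon): ethoxy in place of hydrogen on a saturated chain carbon bound to a carbonyl carbon. This turns acetamido into ((ethoxymethyl)carbonyl)amino.

Among the compounds with values here, no measured pair shows this change by itself, so the expectation is uncertain. Compound 1 also has a substituted chain on its amide carbonyl and gives 510 nM in this assay, but its core differs too, so it offers only a weak hint. A modest weakening is expected, with the estimated size given by (a 1.6-fold higher number from compound 2 to compound 3 (0.22 log units; within the scatter)). The estimated value for compound 3 is 280 nM (expected range 100 nM to 800 nM).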

Compound 3, half-maximal inhibitory concentration: 1230 nM
For compound 3 the middle estimate is 4.4-fold (0.64 log units) below the measured one; the whole stated range lies below it.
By their numbers in this assay, from the lowest: compound 2; then compound 1; then compound 3.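

In this assay the saturated chain carbon bound to the carbonyl carbon of the amide turns out not to be a free place to build on: ethoxy in place of hydrogen there gives a 7.2-fold higher number from compound 2 to compound 3 (0.86 log units; beyond the scatter) and this step lies beyond the usual scatter of repeated measurements, so compound 3 is clearly the weaker inhibitor of the pair. This is the only pair shown that differs in a single place, so this loss, unlike the gap between compound 1 and compound 2, can be tied to one change on the acetamido group. The reason for the loss remains unknown, as no independent measurement bears on this change.

On these data alone, whether any addition at this carbon costs as much stays open, as a single group says little about how a hydroxy group, a carboxylic acid or a longer chain would fare there on the shared core. Also open, as far as these compounds go, is how an amine would behave at this carbon on that core, since the dimethylamino group of compound 1 sits on a different core and cannot settle the question.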